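This account rests on a few compounds, and the source may have more. Where it says the series, first, only, none or still open, it means among the compounds named here.

Measured so far in a functional assay on HCT-116 cells (Homo sapiens) for antiproliferative activity, read by MTT assay, with a stated time of 72 h; a higher number here means a weaker inhibitor, a lower number a stronger inhibitor:
- compound 1 `COc1ccc(/C=C2\S/C(=N\c3ccc(C)c(Cl)c3)N(C)C2=O)cc1`: 14100 nM
- compound 2 `COc1ccc(/C=C2\S/C(=N\c3ccc(C(C)(C)C)cc3)N(C)C2=O)cc1`: > 100000 nM

Compound 2 gives > 100000 nM, which is a limit of the assay and not a number. Going by the values given here, compound 2 therefore has no exact place, and no measured step connects the two compounds.

The next compound is compound 3 `COc1ccc(/C=C2\S/C(=N\c3ccc(Br)cc3)N(C)C2=O)cc1`, with bromo in place of tert-butyl on an aromatic carbon. In this assay the expected change is an at least 5.0-fold lower number from compound 2 to compound 3 (0.69 log units; beyond the scatter), towards stronger inhibition and beyond the usual scatter. As far as these compounds go, its true size remains open, since its starting point is only a limit. Among the compounds with values here, the one numerical reference is compound 1 at 14100 nM, so the expectation is a result near that value. For compound 3 the estimated value is 20000 nM, with an expected range of 6000 nM to 70000 nM.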

Compound 3, half-maximal inhibitory concentration: 17000 nM
The estimate for compound 3 lay 1.2-fold (0.07 log units) above the measured number, and the stated range covers the measured number.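

In this assay compound 2 stands at a limit of the assay and not at a number: the limit of > 100000 nM in this assay, at which 1 of the 3 values shown sits. As far as these compounds go, with bromo in place of tert-butyl on the aromatic carbon, the series returns to a measurable value, giving an at least 5.8-fold lower number from compound 2 to compound 3 (0.76 log units; beyond the scatter); the true size of this step remains open. Compound 3 also shows that the aryl group on the double-bonded nitrogen can be 4-bromophenyl instead of 3-chloro-4-methylphenyl, with a 1.2-fold higher number from compound 1 to compound 3 (0.08 log units; within the scatter), so these two aryl groups cannot be told apart in this assay.

Still open, from the compounds shown here alone, is whether the limit reached with tert-butyl is particular to that group or extends to other branched alkyl groups at this place. How an amine or a carboxylic acid on the same aromatic carbon would read is also unknown.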